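Series notes: terminal ring change, compound 3 to compound 4

A few compounds are considered here, and "the series" means these few. Any claim that something is new, unique, unknown or untested is made for them only; others in the source may bear on it.

Measured in a functional assay on DWD cells (Homo sapiens) for inhibition, read by sulforhodamine B assay; a lower number here means a stronger inhibitor of growth, a higher number a weaker inhibitor of growth:
- compound 1 `Oc1cccc2[nH]c(-c3ccc(-c4ccc(-c5ccc(F)cc5)cc4)cc3)nc12`: 22200 nM
- compound 2 `COc1ccc(-c2ccc(-c3ccc(-c4nc5c(O)cccc5[nH]4)cc3)cc2)cc1`: 6400 nM
- compound 3 `CN(C)c1ccc(-c2ccc(-c3ccc(-c4nc5c(O)cccc5[nH]4)cc3)cc2)cc1`: 9210 nM

Compound 3 stands at 9210 nM. Against its two neighbours, the measured steps are a 1.4-fold higher number from compound 2 to compound 3 (0.16 log units; within the scatter) and a 2.4-fold lower number from compound 1 to compound 3 (0.38 log units; beyond the scatter). Compound 4 `Oc1cccc2[nH]c(-c3ccc(-c4ccc(-c5cccc(Cl)c5)cc4)cc3)nc12` differs from it as follows: 3-chlorophenyl in place of 4-(dimethylamino)phenyl on an aromatic carbon. Going by the values given here, no measured compound carries a 3-chlorophenyl group. The nearest guides are the fluoro-bearing compound 1 at 22200 nM and the modest steps away from it, a 3.5-fold lower number from compound 1 to compound 2 (0.54 log units; beyond the scatter) and a 2.4-fold lower number from compound 1 to compound 3 (0.38 log units; beyond the scatter). A small move towards the number of compound 1 is therefore expected in this assay, estimated as a 1.7-fold higher number from compound 3 to compound 4 (0.24 log units; within the scatter). Compound 4 is expected at 16000 nM, with an estimated range of 7000 nM to 35000 nM.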

Compound 4, concentration for 50% growth inhibition: 2100 nM
Compound 4: middle estimate off by 7.6-fold (0.88 log units), on the high side; the measured number lies below the stated range.
By their numbers in this assay, from the lowest: compound 4; then compounds 2 and 3 (each within the scatter of the next); then compound 1.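

In this assay the 3-chlorophenyl group brings a 4.4-fold lower number from compound 3 to compound 4 (0.64 log units; beyond the scatter) and a 3.0-fold lower number from compound 2 to compound 4 (0.48 log units; beyond the scatter) and also an 11-fold lower number from compound 1 to compound 4 (1.02 log units; beyond the scatter) and so makes compound 4 the strongest inhibitor of growth of the four. The 4-fluorophenyl, 4-methoxyphenyl and 4-(dimethylamino)phenyl groups gave no sign of a gain this large at this position. Nothing measured here accounts for the gain.

From the compounds shown here alone, the chlorine and its place on the ring change together in this step, so it stays open which of the two matters. The 4-chlorophenyl and 3-methoxyphenyl groups would separate them.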